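Vinyl in Place of Trifluoromethyl on the Shared Core

The compounds below may be only part of what the source reports. "The series", "measured", "known", "first", "only" and "open" are said of these compounds alone.

Compound 3 `C/C(=C\c1cc(-c2ccc(C(F)(F)F)cc2)cs1)C(N)=O` is known only through a limit in an ADME assay on NIH3T3 cells (Mus musculus) for cytotoxicity, read by CCK-8 assay, with a stated time of 24 h; a higher number here means a weaker inhibitor, a lower number a stronger inhibitor: compound 3 gives > 50000 nM. Compound 1 `C/C(=C\c1cc(-c2ccc(F)cc2)cs1)C(N)=O` also reaches only the limit, giving > 50000 nM. Compound 2 `C/C(=C\c1cc(-c2ccc(C#N)cc2)cs1)C(N)=O` likewise gives only the limit > 50000 nM. The steps a step that the two limits leave unreadable from compound 1 to compound 2, a step that the two limits leave unreadable from compound 1 to compound 3 and a step that the two limits leave unreadable from compound 2 to compound 3 cannot be sized because every value rests on (the limit of > 50000 nM in this assay, at which 3 of the 3 values shown sit). Compound 4 `C=Cc1ccc(-c2csc(/C=C(\C)C(N)=O)c2)cc1` differs from compound 3 by vinyl in place of trifluoromethyl on an aromatic carbon. For the measured compounds named here, no measured step covers a vinyl group, and the three measured steps give no readable size, so no shift beyond the scatter can be foreseen in this assay. Compound 4 is therefore expected to sit again at the limit, with an estimate of 60000 nM (range 25000 nM to 200000 nM), which is an expected step that the limit leaves unreadable from compound 3 to compound 4.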

Compound 4, half-maximal inhibitory concentration: > 50000 nM
Compound 4: only a limit was reported (the forecaster's own chance of this, stated with the estimate: 80%); the middle value is on the limit's open side.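

No step from compound 1, compound 2 or compound 3 to compound 4 can be read, because all of them rest on the same limit: the limit of > 50000 nM in this assay, at which 4 of the 4 values shown sit.

The compounds shown leave open whether any of them differ in this assay.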